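From a Benzodioxinylmethyl Amine to a Methoxybenzyl Analogue

A few compounds are considered here, and "the series" means these few. Any claim that something is new, unique, unknown or untested is made for them only; others in the source may bear on it.

Three compounds sharing one core were measured in a functional assay on HPAC cells (Homo sapiens) for inhibition, read by MTT assay, with a stated time of 72 h; a lower number here means a stronger inhibitor of growth, a higher number a weaker inhibitor of growth. Compound 1 `O=S(=O)(NCCCCNCc1ccc(Br)cc1)c1cc(C(F)(F)F)cc(C(F)(F)F)c1` gives 2000 nM. Compound 2 `COc1ccc(CNCCCNS(=O)(=O)c2cc(C(F)(F)F)cc(C(F)(F)F)c2)cc1OC` gives 3500 nM, and compound 3 `O=S(=O)(NCCCNCC1COc2ccccc2O1)c1cc(C(F)(F)F)cc(C(F)(F)F)c1` gives 2700 nM. On these numbers compound 3 stands second highest of the three; its nearest neighbour is compound 2 and its furthest is compound 1, and both gaps lie within the scatter, so no ranking among the three can be read from them. Among the compounds with values here, the single change that has been followed in one place, a 1.3-fold lower number from compound 2 to compound 3 (0.11 log units; within the scatter), was likewise within the scatter.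

Compound 4 `COc1ccc(CNCCCNS(=O)(=O)c2cc(C(F)(F)F)cc(C(F)(F)F)c2)cc1` has not yet been measured. Its difference from compound 3 is 4-methoxyphenyl in place of 2,3-dihydro-1,4-benzodioxin-2-yl on a saturated chain carbon bound to an amine nitrogen. Within the data shown here, the only measured step that bears on it is a 1.3-fold lower number from compound 2 to compound 3 (0.11 log units; within the scatter), which altered the same saturated chain carbon bound to the amine nitrogen and moved the number hardly at all; compound 2 carries the 3,4-dimethoxyphenyl group, close in kind to the 4-methoxyphenyl that enters, and its value sits near that of compound 3. On this basis compound 4 is expected to show a 1.1-fold higher number from compound 3 to compound 4 (0.05 log units; within the scatter), a step not beyond the scatter. Compound 4 is therefore estimated at 3000 nM, with a range from 1200 nM to 7500 nM.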

Compound 4, concentration for 50% growth inhibition: 3000 nM
Estimate against measurement, compound 4: no gap at the digits printed, and the stated range covers the measured number.
By their numbers in this assay, from the lowest: compounds 1, 3, 4 and 2 (each within the scatter of the next).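

In this assay, moving from 2,3-dihydro-1,4-benzodioxin-2-yl, with its six-membered non-aromatic ring, to 4-methoxyphenyl on a saturated chain carbon bound to an amine nitrogen leaves the number within the scatter (a 1.1-fold higher number from compound 3 to compound 4 (0.05 log units; within the scatter)), so this second change at the position gives the same reading as the first. Within the data shown here, compound 4 also isolates a change that the earlier compounds did not, hydrogen in place of methoxy on an aromatic carbon, and that step too stays within the scatter (a 1.2-fold lower number from compound 2 to compound 4 (0.07 log units; within the scatter)). The step from the bromobenzyl compound, (4-methoxybenzyl)amino in place of ((4-bromobenzyl)amino)methyl, is likewise within the scatter (a 1.5-fold higher number from compound 1 to compound 4 (0.18 log units; within the scatter)), though it alters the chain and the aromatic substituent together and cannot separate the two.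

No information is available that bears on why these values stay so close. Still open, on these data alone, is whether any other group at this position, such as a pyridine ring, a free phenol or a carboxylic acid, would move the number beyond the scatter, and whether a benzyl group carrying bromo on the shorter chain would read differently from one carrying methoxy.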